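Swapping Carbamoyl for Trifluoromethyl on a Biaryl Arm

The source may report more compounds than this note shows. Statements on the series, on what has been measured and on what is new or still open speak of the compounds shown alone.

Of the compounds shown here, three built on one shared core have been tested in an assay on isolated protein for inhibition of 2-Hydroxyacid oxidase 2 (Homo sapiens), tested at 1 uM; a lower number here means a weaker effect, a higher number a stronger effect of the compound at the concentration tested. Compound 1 `Cc1n[nH]c(C(=O)O)c1Cc1cccc(-c2ccc(C(N)=O)cc2)c1` gives 18%. Compound 2 `Cc1n[nH]c(C(=O)O)c1Cc1cccc(C(N)=O)c1` gives 8%, and compound 3 `Cc1n[nH]c(C(=O)O)c1Cc1cccc(C(F)(F)F)c1` gives 5%. Compound 1 stands highest of the three, but its gap to compound 2 lies within the usual scatter, while its gap to compound 3 lies beyond it. Compound 1 and compound 2 differ in more than one place, so the difference between the two cores is not broken down here.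

Compound 2 and compound 3 differ in one place: trifluoromethyl in place of carbamoyl on an aromatic carbon This change made a number 3 percentage points lower from compound 2 to compound 3 (within the scatter), a step within the scatter.

Compound 4 `Cc1n[nH]c(C(=O)O)c1Cc1cccc(-c2ccc(C(F)(F)F)cc2)c1` has not yet been measured. Within the data shown here, it differs from compound 1 in one place: trifluoromethyl in place of carbamoyl on an aromatic carbon This is the same kind of change as the one from compound 2 to compound 3, but not the same change, since the surroundings of the place differ: in compound 3 the entering group sits meta to a large group, whereas in compound 4 it sits para to a large group. Because a number 3 percentage points lower from compound 2 to compound 3 (within the scatter) stayed within the scatter, the step from compound 1 to compound 4 in this assay is expected to be small as well, estimated at a number 3 percentage points lower from compound 1 to compound 4 (within the scatter). Compound 4 is therefore expected to give about 15% in this assay. The estimate for compound 4 is expected to fall between 5% and 25%.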

Compound 4, a percentage reported as inhibition, at one concentration (the size of the read-out at that concentration, not a potency): 8%
Beside the measured number, compound 4's estimate is 7 percentage points above it; low and high end bracket the measured number.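

In this assay, putting trifluoromethyl in place of carbamoyl on the core of compound 1 gave a number 10 percentage points lower from compound 1 to compound 4 (within the scatter), so on this larger core, too, the change cannot be told apart from the ordinary spread of repeated measurements. Set beside the earlier case on the smaller core, the two steps do not differ by more than that spread allows: the same change on two cores in this assay, a number 3 percentage points lower (within the scatter) from compound 2 to compound 3 and a number 10 percentage points lower (within the scatter) from compound 1 to compound 4, 7 percentage points apart, within the scatter of two such steps. This shows that, on these two cores, the swap behaves alike as far as this read-out can tell, but it does not show that the swap has a real effect on either core, nor that its size is truly the same on both, as neither step stands clear of the scatter.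

The compounds shown leave open whether a different group at this place on the ring, such as an amine, a carboxylic acid or a nitrile, would give a step beyond the scatter on either core. They also leave open whether the swap would behave the same way on a third core, or at another test concentration, as every number here comes from a single concentration.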